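Stepping from Compound 1 to Compound 3

The source may report more compounds than this note shows. Statements on the series, on what has been measured and on what is new or still open speak of the compounds shown alone.

Compound 1 (`c1cc(OCc2ccc3ccccc3n2)cc(OCc2ccccc2-c2nn[nH]n2)c1`) gives 19 nM in a functional assay (lung) for inhibition, with Cavia porcellus as the target; on this read-out higher numbers stand for weaker inhibition and lower numbers for stronger inhibition. Compound 2 (`COc1cc(COc2cccc(OCc3ccc4ccccc4n3)c2)cc(-c2nn[nH]n2)c1`) gives 6.3 nM in this assay. Compound 1 therefore has the higher of the two numbers, which makes it the weaker inhibitor of the pair, and the gap lies beyond the usual scatter.

Compound 3 (`c1cc(OCc2ccc3ccccc3n2)cc(OCc2ccccc2Cc2nnn[nH]2)c1`) has not yet been measured. It carries (1H-tetrazol-5-yl)methyl in place of 2H-tetrazol-5-yl on an aromatic carbon, ortho to a large group ((1H-tetrazol-5-yl)methyl in place of 2H-tetrazol-5-yl on an aromatic carbon). Going by the values given here, no measured pair shows this change on its own, so any forecast is uncertain and the range must be wide. In this assay, no step beyond the scatter is expected, and the estimate amounts to an expected 1.1-fold higher number from compound 1 to compound 3 (0.02 log units; within the scatter). The estimated value for compound 3 is 20 nM, with an expected range of 5 nM to 80 nM.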

Compound 3, half-maximal inhibitory concentration: 9.5 nM
Compound 3: the middle estimate sits 2.1-fold (0.32 log units) above what was measured, within the range that was stated.
By their numbers in this assay, from the lowest: compounds 2, 3 and 1 (each within the scatter of the next, the first and the last beyond it).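

In this assay, putting (1H-tetrazol-5-yl)methyl in place of 2H-tetrazol-5-yl on an aromatic carbon, ortho to a large group, gives a 2.0-fold lower number from compound 1 to compound 3 (0.30 log units; within the scatter) and so leaves the read-out unchanged within the scatter. Going by these compounds alone, this shows something the earlier compounds could not: at this position, the five-membered aromatic ring can be set one carbon further from the six-membered ring without a loss of inhibition in this whole-organism test. Nothing available explains why the two compounds read alike.

This conclusion rests on a single pair, so it does not show how much further the chain can grow, as with a 2-(1H-tetrazol-5-yl)ethyl group. It also leaves open whether the five-membered ring is needed at all, which a carboxylic acid at this position would test.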